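Pyridin-3-yl to Imidazolylmethyl on Two Related Cores

This account rests on a few compounds, and the source may have more. Where it says the series, first, only, none or still open, it means among the compounds named here.

The study examines four compounds in an assay for inhibition of steroid 17-alpha-hydroxylase/17,20 lyase (Homo sapiens), tested at 0.2 uM; a higher number here means a stronger effect of the compound at the concentration tested, a lower number a weaker effect. Compound 1 `COc1ccc2cc(-c3ccc(F)cc3)ccc2c1-c1cccnc1` gives 6% in this assay. Compound 3 `COc1ccc2cc(-c3ccc(F)cc3)ccc2c1Cn1ccnc1` gives 13% in this assay after ((1H-imidazol-1-yl)methyl in place of pyridin-3-yl on an aromatic carbon); that change made a step of a number 7 percentage points higher from compound 1 to compound 3 (within the scatter). Compound 2 `Fc1ccc(-c2ccc3cc(-c4cccnc4)ccc3c2)cc1` gives 0% in this assay; the difference between the core of compound 2 and the core of compound 1 is not broken down here.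

Compound 4 `Fc1ccc(-c2ccc3cc(Cn4ccnc4)ccc3c2)cc1` has not yet been measured. It differs from compound 2 by (1H-imidazol-1-yl)methyl in place of pyridin-3-yl on an aromatic carbon. Among the measured compounds shown here, this is the same kind of change as the one that gave compound 3, but not the same: in compound 1 the place is ortho to a fused ring, ortho to a methoxy group and meta to a fused ring, whereas in compound 2 it is meta to a fused ring and para to a fused ring.

Resting on a number 7 percentage points higher from compound 1 to compound 3 (within the scatter) and on the reading of compound 2, which is 0%, the expected step is a number 6 percentage points higher from compound 2 to compound 4 (within the scatter). Compound 4 is accordingly estimated at 6%, with a range from 0% to 18% in this assay.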

Compound 4, a percentage reported as inhibition, at one concentration (the size of the read-out at that concentration, not a potency): 3%
The estimate for compound 4 lay 3 percentage points above the measured number; the measured number falls inside the stated range.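

In this assay, putting (1H-imidazol-1-yl)methyl in place of pyridin-3-yl on the core of compound 2 gave a number 3 percentage points higher from compound 2 to compound 4 (within the scatter). Set beside the earlier step on the core of compound 1, the change reads the same on both cores as far as these numbers can tell: the same change on two cores in this assay, a number 7 percentage points higher (within the scatter) from compound 1 to compound 3 and a number 3 percentage points higher (within the scatter) from compound 2 to compound 4, 4 percentage points apart, within the scatter of two such steps. Among the compounds shown here, this shows only that the change produced no step beyond the scatter on either core; it does not show a real gain from the change on either one, and two cores read at a single concentration cannot establish how the change would carry over to a further core.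

The compounds shown leave open whether a different group at this place, such as an amine, a carboxylic acid or a longer chain ending in the imidazole, would read differently from pyridin-3-yl on these cores. They also leave open how the two groups would compare at other concentrations.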